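A few compounds are considered here, and "the series" means these few. Any claim that something is new, unique, unknown or untested is made for them only; others in the source may bear on it.

Measured compounds:
- compound 1 `O=c1n(Cc2nc3ccc(C(F)(F)F)cn3c2CCCCO)c2cnccc2n1C1CC1` — in an ADME assay on HEp-2 cells (Homo sapiens) for cytotoxicity, read by CCK-8 assay, with a stated time of 6 days (on this read-out higher numbers stand for lower toxicity in this test and lower numbers for higher toxicity in this test), compound 1 gives > 100000 nM, a limit of the assay.
- compound 2 `O=c1n(Cc2nc3cc(F)ccn3c2CCCCO)c2cnccc2n1C1CC1` — in this assay compound 2 gives > 100000 nM, a limit of the assay.
- compound 3 `N#Cc1c(Cn2c(=O)n(C3CC3)c3ccncc32)nc2cc(Cl)ccn12` — in this assay compound 3 gives 22500 nM.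

Going by the values given here, compound 3 stands as the only genuine number among the three; the other two sit at the limit of > 100000 nM in this assay, at which 2 of the 3 values shown sit, and set no measured step. Compound 4 `O=C(O)/C=C/c1c(Cn2c(=O)n(C3CC3)c3ccncc32)nc2cc(Cl)ccn12` differs from compound 3 by 2-carboxyethenyl in place of cyano on an aromatic carbon. Among the compounds with values here, no measured pair varies only this position, so the size of the step is unanchored. The estimated step of a 2.7-fold higher number from compound 3 to compound 4 (0.43 log units; beyond the scatter) in this assay is taken toward lower toxicity, modestly beyond scatter, with a real chance that only a limit is returned. Compound 4 is expected at 60000 nM, within 18000 nM to 100000 nM.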

Compound 4, half-maximal cytotoxic concentration: > 100000 nM
Compound 4: only a limit was reported; the forecaster's own chance of this, stated with the estimate: 45%; middle value at least 1.6-fold (0.22 log units) away from the limit.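

Going by these compounds alone, at this position, 2-carboxyethenyl in place of cyano gives the first measured step in this assay, toward lower toxicity in this test: an at least 4.4-fold higher number from compound 3 to compound 4 (0.64 log units; beyond the scatter). Compound 4 returns a limit and not a number, so the step has a lower bound only and its full size cannot be read. Compound 4 also joins the other compounds at the top of the read-out: the limit of > 100000 nM in this assay, at which 3 of the 4 values shown sit.

Going by these compounds, whether the carboxylic acid or the ethenyl part carries the step stays open. A methyl ester or a saturated propanoic acid chain at this position would separate the two.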